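This account rests on a few compounds, and the source may have more. Where it says the series, first, only, none or still open, it means among the compounds named here.

Measured compounds:
compound 1, `COc1cccc(CNC(=O)c2nc(Br)c3cccnc3c2N[C@H]2CC[C@H](N)CC2)c1`, 6000 nM
compound 2, `O=C(NCc1ccc(F)cc1)c1nc(Br)c2cccnc2c1NCCCNc1c(C(=O)NCc2ccc(F)cc2)nc(Br)c2cccnc12`, > 20000 nM
compound 3, `C[C@@H](CO)Nc1nc(C(=O)NCc2ccc(F)cc2)c(O)c2ncccc12`, "not determined" (no result reported)

Within the data shown here, in a functional assay on HCT-116 cells (Homo sapiens) for cytotoxicity, read by MTT assay, with a stated time of 72 h (on this read-out lower numbers stand for stronger inhibition and higher numbers for weaker inhibition), compound 1 gives 6000 nM, the only single number among the three entries. Compound 2 gives > 20000 nM, which is a limit of this assay rather than a number (the limit of > 20000 nM in this assay, at which 1 of the 3 values shown sits). For compound 3 this assay reports "not determined" (no result reported), so no number is available.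

Compound 4, `N[C@H]1CC[C@H](Nc2c(C(=O)NCc3ccc(Cl)cc3)nc(Br)c3cccnc23)CC1`, has not yet been measured. It differs from compound 1 in one place: 4-chlorophenyl in place of 3-methoxyphenyl on a saturated chain carbon bound to an amide-type nitrogen. Among the measured compounds shown here, no step between two measured compounds is available to show how much such a swap of one aromatic ring for another changes the result, so the step from compound 1 to compound 4 is expected to stay within the usual scatter, or at most slightly favour compound 4, as a 1.3-fold lower number from compound 1 to compound 4 (0.12 log units; within the scatter). Compound 4 is therefore estimated at 4500 nM, with a range from 1500 nM to 15000 nM.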

Compound 4, half-maximal inhibitory concentration: 4000 nM
Compound 4: middle estimate off by 1.1-fold (0.05 log units), on the high side; the range from low to high includes it.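

Among these compounds, the swap of 3-methoxyphenyl for 4-chlorophenyl gives the first step that can be read at this place: in this assay it is a 1.5-fold lower number from compound 1 to compound 4 (0.18 log units; within the scatter), so the two compounds cannot be told apart. In this pair, the hydrogen-bond acceptor counted in 3-methoxyphenyl can go without a change beyond the scatter. Nothing measured here bears on what lies behind this result. Still open, as far as these compounds go, is whether an aromatic ring is needed here at all, and what a carboxylic acid, an amine or a longer chain would do in its place.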